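The source may hold more compounds than are shown below. What is called first, only, known or untested is meant among the compounds shown, and "the series" means these compounds.

Compounds tested in a functional assay on MOLT-4 cells (Homo sapiens) for antiproliferative activity, read by cell counting, with a stated time of 2 days; a lower number here means a stronger inhibitor, a higher number a weaker inhibitor:

compound 1 `COc1cc(C(=O)c2sc(N)nc2N)cc(OC)c1OC`: "not determined" (no result reported)
compound 2 `CCN(CC)c1nc(N)c(C(=O)c2cc(OC)c(OC)c(OC)c2)s1`: "not determined" (no result reported)
compound 3 `CCCCN(C)c1nc(N)c(C(=O)c2cc(OC)c(OC)c(OC)c2)s1`: 32000 nM

Within the data shown here, compound 3 carries the only number in this small set. The entries for compound 1 and compound 2 hold no result, so compound 3 cannot be ranked against either of them, and its value stands alone as the single reference point.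

The next compound, compound 4 `COc1cc(C(=O)c2sc(N(C)Cc3ccccc3)nc2N)cc(OC)c1OC`, has not yet been measured. It keeps the shared core of compound 3 and differs from it by phenyl in place of propyl on a saturated chain carbon bound to a nitrogen on an aromatic ring. This puts phenyl in place of propyl on a saturated chain carbon bound to a nitrogen on an aromatic ring, so that butyl(methyl)amino becomes benzyl(methyl)amino.

Among the measured compounds shown here, no measured pair shows what such a change does in this assay, so any expectation is loose. With compound 3 at 32000 nM, a moderate move toward stronger inhibition is expected, although a result close to compound 3 would fit the data equally well. The expected change is a 3.6-fold lower number from compound 3 to compound 4 (0.55 log units; beyond the scatter). For compound 4 the estimated value is 9000 nM, with an expected range from 1500 nM to 40000 nM.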

Compound 4, half-maximal inhibitory concentration: > 200000 nM
Compound 4: no number, only a limit (the forecaster's own chance of this, stated with the estimate: 25%); middle value at least 22-fold (1.34 log units) from the limit.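

In this assay, the place on a saturated chain carbon bound to a nitrogen on an aromatic ring now has its first readable step, as phenyl in place of propyl, which turns butyl(methyl)amino into benzyl(methyl)amino, gives an at least 6.2-fold higher number from compound 3 to compound 4 (0.79 log units; beyond the scatter). The reading for compound 4 is a limit of the assay and not a number: the limit of > 200000 nM in this assay, at which 1 of the 4 values shown sits. The size of the change therefore stays unfixed, but its direction is clear, toward weaker inhibition, something that compound 1 and compound 2 could not show, as neither has a result.

On these data alone, whether a cyclohexyl in place of the phenyl, or a longer chain in place of the propyl, would read closer to compound 3 or to compound 4 remains open. As far as these compounds go, with a single pair resting on a limit, it is also open whether the same change would act alike in a compound carrying a different amine, such as a morpholine, at this place.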